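Esterification of the hydroxy in compound 2: expectation for compound 4

The compounds below may be only part of what the source reports. "The series", "measured", "known", "first", "only" and "open" are said of these compounds alone.

Compound 1 `C=C1C(=O)O[C@@H]2CC(C)=C([C@@H](C)CCCOC(C)=O)[C@H](OC(C)=O)[C@H]12`, compound 2 `C=C1C(=O)O[C@@H]2CC(C)=C([C@@H](C)CCCO)[C@H](O)[C@H]12` and compound 3 `C=C1C(=O)O[C@H]2/C=C(\C)CC/C=C(\C)C[C@H](O)[C@@H]12` share a methylene lactone core and have been tested in a functional assay on COLO 205 cells (Homo sapiens) for cytotoxicity, read by trypan blue exclusion, with a stated time of 24 h; on this read-out higher numbers stand for weaker inhibition and lower numbers for stronger inhibition. In this assay compound 1 gives 56700 nM and compound 3 gives 14300 nM. Compound 2 returns only a limit of the assay, > 100000 nM, so no number stands for it. The same limit is reported at the limit of > 100000 nM in this assay, at which 1 of the 3 values shown sits.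

Compound 4 `C=C1C(=O)O[C@@H]2CC(C)=C([C@@H](C)CCCO)[C@H](OC(=O)C(C)CC)[C@H]12` differs from compound 2 in one place: (sec-butyl)carbonyl in place of hydrogen on an oxygen on a saturated carbon. Among the compounds with values here, no step between two measured compounds matches this change, so the expectation for compound 4 rests on the values of compound 1 and compound 3 and on the position of compound 2 at the limit. Compound 2 itself sits at the limit of the assay. The step from compound 2 to compound 4 is expected to be an at least 2.0-fold lower number from compound 2 to compound 4 (0.30 log units; that floor lies within the scatter), toward stronger inhibition, since the esterified compound 1 gives 56700 nM. For compound 4 a value of about 50000 nM is estimated, within 20000 nM to 120000 nM.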

Compound 4, half-maximal inhibitory concentration: 58700 nM
Beside the measured number, compound 4's estimate is 1.2-fold (0.07 log units) below it, and the stated range covers the measured number.
By their numbers in this assay, from the lowest: compound 3; then compounds 1 and 4 (each within the scatter of the next). At a limit, above all of these: compound 2.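

In this assay, the change from hydroxy to ((sec-butyl)carbonyl)oxy now has a step of its own, with an at least 1.7-fold lower number from compound 2 to compound 4 (0.23 log units; that floor lies within the scatter). Compound 2 gives > 100000 nM, which is a limit and not a number: the limit of > 100000 nM in this assay, at which 1 of the 4 values shown sits. Compound 4 gives a number inside the range of this assay with a single ester on the oxygen on a saturated carbon and with the second hydroxy of compound 2 left unchanged.

Open, on these data alone, is whether a benzoyl group or a longer acyl chain in place of (sec-butyl)carbonyl on this oxygen would give a different number, and how an ester on the second hydroxy alone would read. As far as these compounds go, the true size of the step also stays open: only its floor can be read.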